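Spiro-fused oxindole series: paw edema inhibition notes

The source may report more compounds than this note shows. Statements on the series, on what has been measured and on what is new or still open speak of the compounds shown alone.

Measured so far:
Compound 1 `CN1C/C(=C\c2ccccc2)C(=O)[C@]2(C1)[C@@H](c1ccccc1)CN(C)[C@@]21C(=O)Nc2ccccc21` — in a functional assay on the whole organism (strain Wister albino) for inhibition, with Rattus norvegicus as the target, read by paw edema, with stated times of 1 h and 4 h, at a dose of 50 mg/kg by the intraperitoneal route (a lower number here means less inhibition, a higher number more inhibition at the dose given (going by the name of the read-out)), compound 1 gives 126%
Compound 2 `CN1C/C(=C\c2ccc(Br)cc2)C(=O)[C@]2(C1)[C@@H](c1ccc(Br)cc1)CN(C)[C@@]21C(=O)Nc2ccccc21` — in this assay compound 2 gives 118%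

Compound 2 holds the lower of the two numbers, but the gap to compound 1 lies within the scatter of repeated measurements, so the two cannot be ordered against each other. Both carry the free amide hydrogen on the five-membered ring of the shared core.

The next compound to be run is compound 3 `CN1C/C(=C\c2ccc(Br)cc2)C(=O)[C@]2(C1)[C@@H](c1ccc(Br)cc1)CN(C)[C@@]21C(=O)N(C)c2ccccc21`. It differs from compound 2 in one place: methyl in place of hydrogen on an amide-type nitrogen in a ring

Among the measured compounds shown here, no pair of measured compounds shows this change, so there is no measured step to lean on. Nothing in the two numbers in hand points to a direction for it, and the working expectation is a step from compound 2 to compound 3 of a number 6 percentage points lower from compound 2 to compound 3 (within the scatter), that is, none beyond the scatter. On that basis compound 3 is estimated to give 112% in this assay, with a range from 85% to 135%.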

Compound 3, a percentage reported as inhibition, in the whole organism at one dose (the size of the read-out at that dose, not a potency): 82.8%
The estimate for compound 3 lay 29.2 percentage points above the measured number; measured number below the stated range.
By their numbers in this assay, from the lowest: compound 3; then compounds 2 and 1 (each within the scatter of the next).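

Within this assay the change of methyl in place of hydrogen on the amide-type nitrogen in a ring gives a number 35.2 percentage points lower from compound 2 to compound 3 (beyond the scatter) and is the first single change in the series with a step beyond the scatter. This shows that the read-out is sensitive to what sits on this nitrogen, which compounds 1 and 2 could not show, as both carry the amide hydrogen. Nothing at hand gives a measured reason for the drop in this pair.

As far as these compounds go, the finding rests on one pair, so it remains open whether the same change would lower the number on the bromine-free compound 1. From the compounds shown here alone, it also remains open whether the drop is specific to methyl or follows any replacement of the amide hydrogen, a question that an ethyl, benzyl or acetyl group on this nitrogen would help to settle.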